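The compounds below may be only part of what the source reports. "The series", "measured", "known", "first", "only" and "open" are said of these compounds alone.

Measured so far in an ADME assay on microsomes from liver (Mus musculus) for metabolic stability, read by LC-MS, with a stated time of 10 min; on this read-out lower numbers stand for a less stable compound and higher numbers for a more stable compound:
compound 1 `CC(C)N1CCN(c2cccc3c2C[C@H](CN(C)[C@H]2CCCc4cccnc42)NC3)CC1`, 15.1%;
compound 2 `CN(C[C@H]1Cc2c(cccc2N2CCN(Cc3ccccn3)CC2)CN1)[C@H]1CCCc2cccnc21`, 40.4%;
compound 3 `CCN(C[C@H]1Cc2c(cccc2N2CCNCC2)CN1)[C@H]1CCCc2cccnc21`, 53.8%.

Compound 3 stands highest of the three numbers in this assay; compound 2 lies beyond the scatter below it, and compound 1 further still. Compound 4 `CN(C[C@H]1Cc2c(cccc2N2CCNCC2)CN1)[C@H]1CCCc2cccnc21` differs from compound 3 by hydrogen in place of methyl on a saturated chain carbon bound to an amine nitrogen. Among the measured compounds shown here, the one measured step, a number 25.3 percentage points higher from compound 1 to compound 2 (beyond the scatter), concerns an amine nitrogen in a ring and so does not bear directly on this change. Compound 2 also carries the methyl and shows a lower number than compound 3, but the two differ in two places, so no single step can be read from that pair. Compound 4 is therefore expected to stay close to the number of its parent, an expected step of a number 6.8 percentage points lower from compound 3 to compound 4 (within the scatter). The estimate for compound 4 is 47%, with a range of 30% to 64%.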

Compound 4, percent of the compound remaining: 19.9%
Compound 4: middle estimate off by 27.1 percentage points, on the high side, outside the stated range (below it).
By their numbers in this assay, from the lowest: compounds 1 and 4 (each within the scatter of the next); then compound 2; then compound 3.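

Small as it is, the change from ethyl to methyl on the chain amine nitrogen is not neutral in this assay and gives a number 33.9 percentage points lower from compound 3 to compound 4 (beyond the scatter) as its large step. Among the compounds carrying methyl there, the group on the amine nitrogen in a ring also counts: hydrogen in place of (pyridin-2-yl)methyl gives a number 20.5 percentage points lower from compound 2 to compound 4 (beyond the scatter) and hydrogen in place of isopropyl gives a number 4.8 percentage points higher from compound 1 to compound 4 (within the scatter) as its reading. Nothing shown accounts for these steps.

On these data alone, whether a longer chain such as propyl would hold the number of ethyl remains open. So does whether ethyl has the same effect when the ring nitrogen carries isopropyl or (pyridin-2-yl)methyl.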